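The source may hold more compounds than are shown below. What is called first, only, known or untested is meant among the compounds shown, and "the series" means these compounds.

Measured compounds:
compound 1, `CC(C)c1cccc(C(C)C)c1NC(=O)NC(c1ccccc1)c1ccccc1`, gives 45 nM in an assay on microsomes from intestine for inhibition of acyl-CoA:cholesterol acyltransferase (Oryctolagus cuniculus); a lower number here means a stronger inhibitor, a higher number a weaker inhibitor.
compound 2, `CC(C)c1cccc(C(C)C)c1NC(=O)NCC1(c2cccnc2)CCCC1`, gives 97 nM.
compound 3, `O=C(NCC1(c2ccccc2)CCCCC1)Nc1ccccc1`, gives 2300 nM.

Compound 3 has the highest number of the three, and so is the weakest inhibitor in this assay. Its nearest neighbour is compound 2, whose number is lower by a margin well beyond the scatter, and compound 1 lies further off still, also beyond the scatter. Compounds 1 and 2 both carry two isopropyl groups on the aryl ring of the urea, while compound 3 carries a bare phenyl there.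

Compound 4, `Cc1ccccc1NC(=O)NCC1(c2ccccc2)CCCCC1`, differs from compound 3 in one place: methyl in place of hydrogen on an aromatic carbon. The methyl sits on the ring ortho to a large group. Among the measured compounds shown here, no step between measured compounds isolates this change, so what compounds 1 and 2 show relative to compound 3 is only a rough guide: substitution on that ring goes with lower numbers.

On that basis a modest gain in potency for compound 4 is expected, that is a 2.9-fold lower number from compound 3 to compound 4 (0.46 log units; beyond the scatter), a step of moderate size toward a lower number. Compound 4 is therefore estimated at 800 nM, with a range from 250 nM to 2500 nM.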

Compound 4, half-maximal inhibitory concentration: 640 nM
Compound 4: the middle estimate sits 1.3-fold (0.10 log units) above what was measured, and the stated range covers the measured number.
By their numbers in this assay, from the lowest: compound 1; then compound 2; then compound 4; then compound 3.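

Going from phenyl to 2-methylphenyl on the urea gives, in this assay, a 3.6-fold lower number from compound 3 to compound 4 (0.56 log units; beyond the scatter). This modest step shows that a single methyl on an aromatic carbon, ortho to a large group, is enough on its own to move the number beyond the scatter. The earlier compounds shown here could not show this: compounds 1 and 2 differ from compound 3 in more than one place, so their lower numbers could not be tied to this ring alone. No measurement shown here accounts for the step.

The compounds shown leave open whether an ethyl, an isopropyl or a methoxy at this same place would move the number further than the methyl does, and whether a second methyl on the same ring would add to the step. They also leave open whether a methyl here would give a step of similar size with the other side of the urea changed, since that side of compounds 1 and 2 differs from that of compound 3.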